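A few compounds are considered here, and "the series" means these few. Any claim that something is new, unique, unknown or untested is made for them only; others in the source may bear on it.

Of the compounds shown here, two in this set have been measured in a functional assay on BXPC-3 cells (Homo sapiens) for inhibition, read by MTT assay, with a stated time of 72 h; a lower number here means a stronger inhibitor of growth, a higher number a weaker inhibitor of growth. Compound 1 `CC(C)(C)c1ccc(CNCCNS(=O)(=O)c2cc(C(F)(F)F)cc(C(F)(F)F)c2)cc1` gives 8800 nM in this assay. Compound 2 `CC(C)(C)c1ccc(CNCCCNS(=O)(=O)c2cc(C(F)(F)F)cc(C(F)(F)F)c2)cc1` carries one more carbon in the chain that links its two nitrogens, and in this assay compound 2 gives 1400 nM. Of the two numbers, compound 2 has the lower one, and the gap between compound 2 and compound 1 lies beyond the usual scatter of this assay, so compound 2 is the stronger growth inhibitor of the pair.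

Compound 3 `O=S(=O)(NCCCNCc1ccccc1)c1cc(C(F)(F)F)cc(C(F)(F)F)c1` keeps the longer chain of compound 2 and its trifluoromethyl-bearing sulfonamide, with a single change: hydrogen in place of tert-butyl on an aromatic carbon. Within the data shown here, no measured pair in this set shows the effect of that particular change, so the expectation has to rest on the structural change alone. Removing that group is expected to weaken growth inhibition to a modest degree, a step of a 2.9-fold higher number from compound 2 to compound 3 (0.46 log units; beyond the scatter) in this assay. Compound 3 is therefore estimated to give 4000 nM in this assay, within a range from 1500 nM to 12000 nM.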

Compound 3, concentration for 50% growth inhibition: 13000 nM
For compound 3 the middle estimate is 3.3-fold (0.51 log units) below the measured one; measured number outside the range, above it.
By their numbers in this assay, from the lowest: compound 2; then compounds 1 and 3 (each within the scatter of the next).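

Replacing tert-butyl with hydrogen on this aromatic carbon, which turns 4-(tert-butyl)benzyl into benzyl, gives a clear loss of growth inhibition in this assay: a 9.3-fold higher number from compound 2 to compound 3 (0.97 log units; beyond the scatter). Among these compounds, this is the first measured read of this position in the set, since the earlier pair differed only in the chain that links the two nitrogens. It shows that, with the longer chain and the sulfonamide held constant, the activity of compound 2 depends strongly on the group at this place, even though the group that leaves is only four carbons with no hydrogen-bond donors or acceptors. Nothing available here explains why the number rises when the group is removed.

The compounds shown place only tert-butyl and hydrogen on this carbon, so it remains open where a methyl, an isopropyl or a methoxy group would fall between those two results. From the compounds shown here alone, it also remains open whether the same change would have a step of similar size on the shorter chain of compound 1.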